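Benzyl swap on a piperidinol core tested for hydrolase inhibition

The source may report more compounds than this note shows. Statements on the series, on what has been measured and on what is new or still open speak of the compounds shown alone.

compound 1 `N#Cc1ccc(CN2CCC(O)(Cn3cnc4c(cnn4-c4ccc(F)cc4)c3=O)CC2)cc1`: "not determined" (no result reported)
compound 2 `O=c1c2cnn(-c3ccc(F)cc3)c2ncn1CC1(O)CCN(Cc2ccc(C(F)(F)F)cc2)CC1`: "not determined" (no result reported)
compound 3 `O=c1c2cnn(-c3ccc(F)cc3)c2ncn1CC1(O)CCN(Cc2ccc(Cl)cc2Cl)CC1`: 3300 nM
compound 4 `COC(=O)c1ccc(CN2CCC(O)(Cn3cnc4c(cnn4-c4ccc(F)cc4)c3=O)CC2)c(Br)c1`: to be measured

Among the compounds with values here, in an assay on Sf21 cells for inhibition of ubiquitin carboxyl-terminal hydrolase 7 (Homo sapiens), read by spectrophotometry, with stated times of 30 min and 2 h (on this read-out higher numbers stand for weaker inhibition and lower numbers for stronger inhibition), compound 3 gives 3300 nM, the only number in this set. In this assay compound 1 has "not determined" (no result reported) and compound 2 has "not determined" (no result reported). Compound 4 differs from compound 3 by 2-bromo-4-(methoxycarbonyl)phenyl in place of 2,4-dichlorophenyl on a saturated chain carbon bound to an amine nitrogen in a ring. Within the data shown here, no step between measured compounds exists here, so no expectation can be drawn from a neighbouring pair, and the change is judged on its own. Because the single anchor is 3300 nM for compound 3, the step from compound 3 to compound 4 is expected to be small, a 1.2-fold higher number from compound 3 to compound 4 (0.08 log units; within the scatter), within or barely beyond the scatter. Compound 4 is therefore estimated at 4000 nM, ranging from 1500 nM to 12000 nM.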

Compound 4, half-maximal inhibitory concentration: 900 nM
Compound 4: the middle estimate sits 4.4-fold (0.65 log units) above what was measured, and the stated range ends above it.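

In this assay, within the data shown here, 2-bromo-4-(methoxycarbonyl)phenyl in place of 2,4-dichlorophenyl gives a 3.7-fold lower number from compound 3 to compound 4 (0.56 log units; beyond the scatter), the only readable step here, showing that this place on a saturated chain carbon bound to an amine nitrogen in a ring accepts the larger group, with its two hydrogen-bond acceptors, and still gains inhibition. Compounds 1 and 2 carry no number, so steps to them cannot be read. Nothing given here accounts for the gain. The compounds shown leave open whether the bromine or the methoxycarbonyl group carries the step, and whether a carboxylic acid in place of that ester would keep it.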